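Alkene Geometry and Cytotoxicity in Human Fibroblasts

The compounds below may be only part of what the source reports. "The series", "measured", "known", "first", "only" and "open" are said of these compounds alone.

compound 1 `Nc1ncnc2c1ncn2/C=C1/C[C@H]1[C@H](O)CO` — 206000 nM
compound 2 `Nc1nc2c(ncn2/C=C2/C[C@@H]2[C@H](O)CO)c(=O)[nH]1` — > 300000 nM
compound 3 `Nc1nc2c(ncn2/C=C2/CC2(CO)CO)c(=O)[nH]1` — > 100000 nM

Three compounds were measured in an ADME assay on HFF cells (Homo sapiens) for cytotoxicity, read by neutral red uptake; on this read-out higher numbers stand for lower toxicity in this test and lower numbers for higher toxicity in this test. Going by the values given here, compound 1 gives 206000 nM, the only plain number among the three. For compound 2 the result is a limit of the test, > 300000 nM. For compound 3 the result is likewise a limit, > 100000 nM. Compound 4 `Nc1ncnc2c1ncn2/C=C1\C[C@H]1[C@H](O)CO` has not yet been measured. It differs from compound 1 in this way: the two compounds have the same atoms and bonds and differ only in configuration as drawn: 1 of 3 stereo elements differ; a double bond is drawn Z in compound 1 and E in compound 4. Among the compounds with values here, no step between measured compounds is available, so the size of the change in this assay is uncertain. The step of a 1.0-fold lower number from compound 1 to compound 4 (0.01 log units; within the scatter) is expected to stay within the usual scatter. Compound 4 is estimated at 200000 nM, expected to lie between 80000 nM and 500000 nM.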

Compound 4, half-maximal cytotoxic concentration: 194000 nM
The estimate for compound 4 lay 1.0-fold (0.01 log units) above the measured number, and the stated range covers the measured number.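

Turning the double bond from Z to E gives a 1.1-fold lower number from compound 1 to compound 4 (0.03 log units; within the scatter) in this assay. This is the first single change that can be read here, and in this test the geometry of this double bond does not separate the two compounds: the fact that compounds 1 and 4 differ only in the configuration as drawn

As far as these compounds go, whether the geometry stays equally silent with an amine or a carboxylic acid in place of the hydroxyl groups remains open. Compound 2 gives only a limit of the assay, > 300000 nM, so it cannot show how the geometry would read on its own core.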